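Changing the amine on compound 2

The source may report more compounds than this note shows. Statements on the series, on what has been measured and on what is new or still open speak of the compounds shown alone.

compound 1 `C/C1=C\CC[C@@]2(C)O[C@@H]2[C@H]2OC(=O)[C@@H](CN3CCCC3)[C@@H]2C[C@H]1O` gives 15000 nM
compound 2 `C/C1=C\CC[C@@]2(C)O[C@@H]2[C@H]2OC(=O)[C@@H](CN3CCCC3)[C@@H]2C[C@@H]1O` gives 10000 nM

In a functional assay on Hs 683 cells (Homo sapiens) for inhibition, read by colorimetric assay and MTT assay, with a stated time of 72 h (on this read-out lower numbers stand for stronger inhibition and higher numbers for weaker inhibition), compound 2 gives 10000 nM and stands level with compound 1 (15000 nM), since the gap lies within the scatter. Compound 3 `C/C1=C\CC[C@@]2(C)O[C@@H]2[C@H]2OC(=O)[C@@H](CN3CCN(C)CC3)[C@@H]2C[C@@H]1O` carries 4-methylpiperazin-1-yl in place of pyrrolidin-1-yl on a saturated chain carbon bound to a saturated ring carbon. Within the data shown here, the only measured step (a 1.5-fold lower number from compound 1 to compound 2 (0.18 log units; within the scatter)) concerns configuration alone (the fact that compounds 1 and 2 differ only in the configuration as drawn), so it bears only indirectly on this change. No step beyond the scatter is therefore expected in this assay for this swap. The estimated step (a 1.2-fold higher number from compound 2 to compound 3 (0.08 log units; within the scatter)) is accordingly small. For compound 3 the estimated value is 12000 nM (range 5000 nM to 30000 nM).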

Compound 3, half-maximal inhibitory concentration: 22000 nM
Beside the measured number, compound 3's estimate is 1.8-fold (0.26 log units) below it, and the stated range covers the measured number.
By their numbers in this assay, from the lowest: compounds 2, 1 and 3 (each within the scatter of the next, the first and the last beyond it).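

Among these compounds, this position responds to the amine it carries: with 4-methylpiperazin-1-yl in place of pyrrolidin-1-yl, this assay shows a 2.2-fold higher number from compound 2 to compound 3 (0.34 log units; beyond the scatter), the first step here beyond the scatter. The step is modest and points towards weaker inhibition, so this swap does not improve on compound 2. Nothing shown explains the step.

Open, from the compounds shown here alone, is where other amines, such as piperidin-1-yl or morpholin-4-yl, would fall at this position relative to compound 2 and compound 3. Also open, going by these compounds, is whether the same swap would have a similar effect on compound 1, with its other configuration.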